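The source may hold more compounds than are shown below. What is called first, only, known or untested is meant among the compounds shown, and "the series" means these compounds.

In a functional assay on A2780 cells (Homo sapiens) for inhibition (on this read-out higher numbers stand for weaker inhibition and lower numbers for stronger inhibition), compound 1 (`CC(C(=O)Nc1cc(C2CC2)[nH]n1)c1ccc(N2C(=O)CCC2c2ccccc2)cc1`) gives 15300 nM, while compound 2 (`CC(C(=O)Nc1cc(C2CC2)[nH]n1)c1ccc(N2CCC(C(N)=O)C2=O)cc1`) gives 5710 nM. Compound 2 therefore holds the lower of the two numbers, and its gap to compound 1 lies beyond the scatter. Compound 3 (`CC(C(=O)Nc1cc(C2CC2)[nH]n1)c1ccc(-n2ccnc2O)cc1`) has not yet been measured. It differs from compound 2 by one change on an aromatic carbon: a group of 6 heavy atoms (3 carbon, 2 nitrogen, 1 oxygen; one five-membered aromatic ring with 2 hetero atoms) in place of a group of 9 heavy atoms (5 carbon, 2 nitrogen, 2 oxygen; one five-membered non-aromatic ring with 1 hetero atom), on an aromatic carbon. For the measured compounds named here, no measured pair shows the effect of this exact change, so the data give no direct size for the step. Going by the values given here, the only guide is the pair of values already in hand, with compound 1 at 15300 nM and compound 2 at 5710 nM. A modest move towards weaker inhibition is expected, not beyond the scatter: a 1.4-fold higher number from compound 2 to compound 3 (0.15 log units; within the scatter). The estimated value for compound 3 is 8000 nM, with an expected range from 2500 nM to 25000 nM.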

Compound 3, half-maximal inhibitory concentration: 6980 nM
Compound 3: middle estimate off by 1.1-fold (0.06 log units), on the high side; low and high end bracket the measured number.
By their numbers in this assay, from the lowest: compounds 2 and 3 (each within the scatter of the next); then compound 1.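

In this assay, replacing the group of 9 heavy atoms with the group of 6 heavy atoms gives a 1.2-fold higher number from compound 2 to compound 3 (0.09 log units; within the scatter). At this aromatic carbon, para to a large group, the five-membered non-aromatic ring with 1 hetero atom can therefore give way to a smaller, five-membered aromatic ring with 2 hetero atoms while the two numbers stay within the scatter of each other, something compound 1 and compound 2 could not show. No other measurement bears on this result.

The compounds shown leave open how an amine or a carboxylic acid on the five-membered aromatic ring would compare with the oxygen that compound 3 carries there. They also leave open how a six-membered aromatic ring at this position would compare with compound 3 at 6980 nM.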